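Removing a Methoxy Group From a Steroid Triazole Sulfonate

The source may hold more compounds than are shown below. What is called first, only, known or untested is meant among the compounds shown, and "the series" means these compounds.

Of the compounds shown here, two have so far been measured in a functional assay on SW480 cells (Homo sapiens) for cytotoxicity, read by MTT assay, with a stated time of 4 days; on this read-out lower numbers stand for stronger inhibition and higher numbers for weaker inhibition. Compound 1 `Cc1ccc(S(=O)(=O)Oc2ccc3c(c2C)[C@H](Cn2cc(-c4ccc(F)cc4)nn2)[C@@]24CC(=O)[C@@](C)(CC[C@@H]32)C4)cc1` carries a fluoro group on an aromatic carbon of its phenyl ring. In this assay compound 1 gives > 20000 nM, which is a limit of the assay rather than a number. Compound 2 `COc1ccc(-c2cn(C[C@H]3c4c(ccc(OS(=O)(=O)c5ccc(C)cc5)c4C)[C@@H]4CC[C@@]5(C)C[C@]43CC5=O)nn2)cc1` has a methoxy in place of fluoro on that aromatic carbon. In this assay compound 2 gives > 20000 nM, again a limit of the assay and not a number. The step that the two limits leave unreadable from compound 1 to compound 2 therefore cannot be read, because both values sit at the limit of > 20000 nM in this assay, at which 2 of the 2 values shown sit. Compound 2 thus stands at the weak end of what this assay can report, with no number of its own.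

Compound 3 `Cc1ccc(S(=O)(=O)Oc2ccc3c(c2C)[C@H](Cn2cc(-c4ccccc4)nn2)[C@@]24CC(=O)[C@@](C)(CC[C@@H]32)C4)cc1` differs from compound 2 by hydrogen in place of methoxy on an aromatic carbon. Among the compounds with values here, no measured step bears directly on removing a methoxy, and the one step available is unreadable. The step that the limit leaves unreadable from compound 2 to compound 3 is expected to be small. Compound 3 is therefore expected to give about 30000 nM in this assay, within a range from 10000 nM to 100000 nM, most likely reported again only as a limit.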

Compound 3, half-maximal inhibitory concentration: > 20000 nM
Compound 3 ended at the assay's limit; the forecaster's own chance of this, stated with the estimate: 85%; the middle value is on the limit's open side.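

Compound 3 adds no readable step: its steps from compound 1 and from compound 2 cannot be read, because in this assay all three compounds give a limit of the assay and not a number: the limit of > 20000 nM in this assay, at which 3 of the 3 values shown sit.

From the compounds shown here alone, whether fluoro, methoxy or hydrogen on this aromatic ring makes any difference stays open, as does what change to the shared core would bring a value within the assay's range.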